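Aryl swap on the ring nitrogen of compound 1

A few compounds are considered here, and "the series" means these few. Any claim that something is new, unique, unknown or untested is made for them only; others in the source may bear on it.

Going by the values given here, compound 1 `CCOC(=O)C1=Cc2ccccc2OC1(OCc1cn(-c2ccc(C)cc2)nn1)C(F)(F)F` is the one member of the set that returns a number in a functional assay on DU-145 cells (Homo sapiens) for inhibition, read by MTT assay, with a stated time of 24 h; on this read-out lower numbers stand for stronger inhibition and higher numbers for weaker inhibition: compound 1 gives 30200 nM. Compound 2 `O=C(O)C1=Cc2ccccc2OC1(OCc1cc(-c2ccc(F)cc2F)no1)C(F)(F)F` reaches only the limit of this assay, reported as > 150000 nM. Compound 3 `CCOC(=O)C1=Cc2ccccc2OC1(OCc1cc(-c2ccc([N+](=O)[O-])cc2)no1)C(F)(F)F` also stops at the limit, given as > 150000 nM. Most of the set therefore sits at the limit rather than at a number, (the limit of > 150000 nM in this assay, at which 2 of the 3 values shown sit), and compound 1 stands alone as the measured point.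

Compound 4 `CCOC(=O)C1=Cc2ccccc2OC1(OCc1cn(-c2cccc(OC)c2)nn1)C(F)(F)F` has not been measured in this assay. It differs from compound 1 by 3-methoxyphenyl in place of 4-methylphenyl on an aromatic nitrogen. Among the compounds with values here, no two measured compounds differ in a single place, so no measured step sets a scale for this change, and the two limits say nothing about the size of a move from one substituted phenyl to another on that ring nitrogen.

In this assay compound 4 is expected to stay close to compound 1, with an expected step of a 1.2-fold higher number from compound 1 to compound 4 (0.06 log units; within the scatter) that lies within the usual scatter. The estimate for compound 4 is 35000 nM, with a range from 12000 nM to 100000 nM.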

Compound 4, half-maximal inhibitory concentration: > 150000 nM
Compound 4 ended at the assay's limit; the forecaster's own chance of this, stated with the estimate: 20%; at least 4.2-fold (0.63 log units) between middle value and limit.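

Going by these compounds alone, on the ring nitrogen, 3-methoxyphenyl in place of 4-methylphenyl gives an at least 4.9-fold higher number from compound 1 to compound 4 (0.69 log units; beyond the scatter) in this assay and so supplies the first single-place comparison, which the earlier compounds could not provide. Within the data shown here, this position is therefore not indifferent to the choice of substituted phenyl, since this one change takes the series from its only numerical value to a limit. Compound 1 remains the sole measured point, with the other values all being limits: the limit of > 150000 nM in this assay, at which 3 of the 4 values shown sit.

The step can only be read as a minimum, and it changes both the substituent and its place on the phenyl ring, so the compounds shown do not separate these two factors. On these data alone, how a plain phenyl or a benzyl group on the ring nitrogen would read remains open.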